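This account rests on a few compounds, and the source may have more. Where it says the series, first, only, none or still open, it means among the compounds named here.

Compound 1 `O=C(CCCCCc1ccc(Cl)cc1)N1CCOC1=O`: 4600 nM
Compound 2 `O=C(O)c1ccc(CCCCCC(=O)N2CCOC2=O)cc1`: > 20000 nM

In an assay on HEK293 cells for inhibition of N-acylethanolamine-hydrolyzing acid amidase (Rattus norvegicus), read by LC-MS, with a stated time of 30 min (on this read-out lower numbers stand for stronger inhibition and higher numbers for weaker inhibition), compound 1 gives 4600 nM. For compound 2, > 20000 nM is only a limit of this assay (the limit of > 20000 nM in this assay, at which 1 of the 2 values shown sits); compound 2 therefore stands at that limit, with no number of its own. Among the compounds with values here, the single measured step, an at least 4.3-fold higher number from compound 1 to compound 2 (0.63 log units; beyond the scatter), runs from chloro to carboxy. Compound 3 `O=C(CCCCCc1ccc(C(F)(F)F)cc1)N1CCOC1=O` takes the other direction: trifluoromethyl in place of carboxy on an aromatic carbon. Removing the carboxy is expected to undo that step, so compound 3 is expected to land near the level of compound 1. The estimated value for compound 3 is 4000 nM, within 1500 nM to 12000 nM. This estimate means an expected step of an at least 5.0-fold lower number from compound 2 to compound 3 (0.69 log units; beyond the scatter).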

Compound 3, half-maximal inhibitory concentration: 1040 nM
Compound 3: the middle estimate sits 3.8-fold (0.59 log units) above what was measured; the measured number lies below the stated range.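

In this assay, chloro is not the best group seen at this place on the aromatic ring: trifluoromethyl gives a 4.4-fold lower number from compound 1 to compound 3 (0.65 log units; beyond the scatter) and so moves beyond the scatter in the stronger direction, which the earlier step away from chloro did not show. Going by these compounds, the change from carboxy (an at least 19-fold lower number from compound 2 to compound 3 (1.28 log units; beyond the scatter)) is large, but its full size stays unknown. Compound 2 has only a limit: the limit of > 20000 nM in this assay, at which 1 of the 3 values shown sits.

On these data alone, whether other groups at this place, such as a nitrile, a methoxy or an amine, match trifluoromethyl remains open. So does how a shorter or longer chain would act alongside it.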